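Swapping a Methoxy for Hydrogen on Compound 2

A few compounds are considered here, and "the series" means these few. Any claim that something is new, unique, unknown or untested is made for them only; others in the source may bear on it.

Among the measured compounds shown here, in an ADME assay on HepG2 cells (Homo sapiens) for cytotoxicity, read by CellTiter-Glo, with a stated time of 72 h (a higher number here means that more compound is needed for the effect, a lower number that less compound is needed), compound 1 (`CC1=C2CC(C)(C)/C=C/C(=O)/C(C)=C\C3=C[C@H](C)C[C@]3(O2)[C@@]1(O)C#N`) gives 26000 nM and compound 2 (`COc1ccc(/C2=C\C(=O)/C(C)=C\C3=C[C@H](C)C[C@@]34OC(=C(C)C4=O)CC2(C)C)cc1`) gives 26000 nM, so compound 2 stands level with the only other measured compound. Compound 3 (`CC1=C2CC(C)(C)/C(c3ccccc3)=C/C(=O)/C(C)=C\C3=C[C@H](C)C[C@]3(O2)C1=O`) has hydrogen in place of methoxy on an aromatic carbon, para to a large group, turning 4-methoxyphenyl into phenyl (hydrogen in place of methoxy on an aromatic carbon). For the measured compounds named here, no measured pair shows this change, so no shift beyond the scatter is expected in this assay, in either direction. The estimated change is no change at the digits printed from compound 2 to compound 3 (within the scatter). For compound 3, the expected value is 26000 nM, with an estimated range of 11000 nM to 55000 nM.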

Compound 3, half-maximal effective concentration: 26000 nM
For compound 3 middle estimate and measured number coincide at the digits printed; the range from low to high includes it.
By their numbers in this assay, from the lowest: compounds 1, 2 and 3 (each within the scatter of the next).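

In this assay there is no change at the digits printed from compound 2 to compound 3 (within the scatter) when hydrogen takes the place of methoxy on the aromatic carbon, turning 4-methoxyphenyl into phenyl. Among the compounds shown here, this is the first comparison of compounds that differ in one place, and it shows that this methoxy can go without a visible shift in this read-out. Nothing measured here offers a reason for this result. The compounds shown leave open whether an amine or a carboxylic acid on that same carbon would also leave the number in place. One pair also cannot say whether this swap would read the same on another core.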